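The source may hold more compounds than are shown below. What is called first, only, known or untested is meant among the compounds shown, and "the series" means these compounds.

Measured so far:

Compound 1, `Cc1ccc(Oc2ccc3nc(COc4cccc(C(=O)O)c4)n(C)c3n2)cc1`, gives 12.6 10^-6 cm/s in an ADME assay for permeability, using PAMPA, with a stated time of 4 h; on this read-out lower numbers stand for lower permeability and higher numbers for higher permeability.
Compound 2, `Cn1c(COc2cccc(C(=O)O)c2)nc2cnc(Oc3ccc4c(c3)OCC4)cc21`, gives 3.6 10^-6 cm/s in this assay.
Compound 3, `Cc1cccc(Oc2ccc3nc(COc4cccc(C(=O)O)c4)n(C)c3c2)n1`, gives 2.7 10^-6 cm/s in this assay.

The three compounds share a common core and differ in the aromatic group attached through an oxygen to that core. Among the three numbers, compound 3 sits at the low end: its value is within the usual scatter of compound 2, while compound 1 stands clearly higher, by a gap beyond the scatter.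

The next compound, compound 4, `Cc1cc(Cl)cnc1Oc1ccc2nc(COc3cccc(C(=O)O)c3)n(C)c2c1`, has not yet been measured. It differs from compound 3 in one place: 5-chloro-3-methylpyridin-2-yl in place of 6-methylpyridin-2-yl on an oxygen on an aromatic ring.

Among the compounds with values here, no measured pair in this set shows this change, so its effect can only be guessed. Compound 4 is expected to stay close to compound 3, with at most a small rise of a 1.5-fold higher number from compound 3 to compound 4 (0.17 log units; within the scatter) in this assay. The estimate for compound 4 is 4 10^-6 cm/s, with a range from 1.5 10^-6 cm/s to 10 10^-6 cm/s.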

Compound 4, apparent permeability: 13.7 10^-6 cm/s
Compound 4: middle estimate off by 3.4-fold (0.53 log units), on the low side; measured number outside the range, above it.
By their numbers in this assay, from the lowest: compounds 3 and 2 (each within the scatter of the next); then compounds 1 and 4 (each within the scatter of the next).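

Putting 5-chloro-3-methylpyridin-2-yl in place of 6-methylpyridin-2-yl on the oxygen gives a 5.1-fold higher number from compound 3 to compound 4 (0.71 log units; beyond the scatter) in this assay. Within the data shown here, this is the first step in the set where only one place differs, and it shows that the group on this oxygen can move the read-out by more than the usual scatter. No measurement shown here accounts for the size of this step.

The two groups differ both in the chlorine and in where the methyl sits, so the step cannot be assigned to either difference until 3-methylpyridin-2-yl or 5-chloropyridin-2-yl is compared on the same core. On these data alone, it also remains open whether a fluorine or a nitrile in place of the chlorine would give a similar step, and whether the same change would do so on the core of compound 1.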